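The source may hold more compounds than are shown below. What is called first, only, known or untested is meant among the compounds shown, and "the series" means these compounds.

Compound 1 `COc1cc2c(cc1N1C[C@@H](C)N[C@@H](C)C1)N(S(=O)(=O)c1ccc(-c3ccccn3)s1)CC2`: 0.9
Compound 2 `COc1cc2c(cc1N1C[C@H](C)NC(C)(C)C1)N(S(=O)(=O)c1ccc(-c3ccccn3)s1)CC2`: 1

In a functional assay with growth hormone secretagogue receptor type 1 (Homo sapiens) as the target (a lower number here means a smaller maximal response, a higher number a larger maximal response), compound 2 gives 1, while compound 1 gives 0.9. For the measured compounds named here, the only step recorded between them, a number 0.10 higher from compound 1 to compound 2 (within the scatter), lies within the scatter, so the two compounds stand together at the level of the reference agonist rather than in any order.

Compound 3 `COc1cc2c(cc1N1C[C@@H](C)NC(C)(C)C1)N(S(=O)(=O)c1ccc(-c3ccccn3)s1)CC2` has not yet been measured. It differs from compound 2 only in configuration: the two compounds have the same atoms and bonds and differ only in configuration as drawn: 1 of 1 stereo elements differ; a stereocentre at a saturated ring carbon is drawn S in compound 2 and R in compound 3.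

Going by the values given here, no measured pair shows what inverting this stereocentre does to the maximal response. Among the compounds with values here, the single known step, which exchanges one saturated ring group for another on an aromatic carbon, is itself within the scatter and does not bear directly on the present change. With both measured compounds reaching the full response of the reference agonist, compound 3 is expected to do much the same, estimated at 0.95 in this assay, within 0.7 to 1.1. The expected step is a number 0.050 lower from compound 2 to compound 3 (within the scatter), no larger than the scatter.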

Compound 3, intrinsic activity: the largest response reached, as a fraction of the reference agonist's: 0.8
For compound 3 the middle estimate is 0.15 above the measured one, within the range that was stated.
By their numbers in this assay, from the lowest: compounds 3, 1 and 2 (each within the scatter of the next, the first and the last beyond it).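

In this assay, for the compounds shown here, inverting the stereocentre at the saturated ring carbon gives a number 0.20 lower from compound 2 to compound 3 (beyond the scatter), the first step to pass beyond the scatter, which shows that the maximal response at this receptor can respond to the configuration at this position. The step can be assigned to that stereocentre alone, because nothing else separates the two compounds: the fact that compounds 2 and 3 differ only in the configuration as drawn The effect remains limited, since compound 3 still gives 0.8, and the comparison with the other ring group gives a number 0.10 lower from compound 1 to compound 3 (within the scatter), so compound 1 cannot be set apart from compound 3 any more than from compound 2.

What the compounds shown leave open is whether the same inversion would lower the response in a ring without the two methyl groups on the other ring carbon, as only this one pair of mirror-drawn centres can be read. Going by these compounds, it also remains open whether an ethyl or hydroxymethyl group in place of the methyl on the stereocentre would widen or close the gap between the two configurations.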